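A hydroxy group on compound 1

The compounds below may be only part of what the source reports. "The series", "measured", "known", "first", "only" and "open" are said of these compounds alone.

In an ADME assay on L6 cells (Rattus norvegicus) for cytotoxicity (a lower number here means a stronger inhibitor, a higher number a weaker inhibitor), compound 1 `CC(C)NC(=N)c1ccc(-c2cc3cc(C(=N)NC(C)C)ccc3o2)cc1` gives > 198000 nM, which is a limit of the assay and not a number. Compound 3 `COc1cc(C(=N)NC(C)C)cc2cc(-c3ccc(C(=N)NC(C)C)cc3)oc12` gives > 190000 nM, also a limit. Compound 2 `c1cc(C2=NCCN2)cc(-c2cc3ccc(C4=NCCN4)cc3o2)c1`, which differs in more than one place, gives a true number of 12800 nM in this assay. Compound 4 `CC(C)NC(=N)c1ccc(-c2cc3cc(C(=N)NC(C)C)ccc3o2)c(O)c1` carries one change from compound 1: hydroxy in place of hydrogen on an aromatic carbon. Within the data shown here, the one measured step that bears on it, a step that the two limits leave unreadable from compound 1 to compound 3, adds methoxy in place of hydrogen on an aromatic carbon, so compound 3 offers no size to carry over and no large shift is expected. The expected step is an at least 1.6-fold lower number from compound 1 to compound 4 (0.21 log units; that floor lies within the scatter), most likely toward a slightly stronger inhibitor. For compound 4 the estimated value is 120000 nM, with an expected range from 35000 nM to 250000 nM.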

Compound 4, half-maximal inhibitory concentration: > 183000 nM
Compound 4: a limit, no number; the forecaster's own chance of this, stated with the estimate: 45%; middle value at least 1.5-fold (0.18 log units) from the limit.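

Compound 1 and compound 4 both give limits in this assay, not numbers, and the step between them cannot be read. The compounds shown leave open what size of change, if any, the hydroxy group brings.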